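Ester-bearing analogue of compound 1 in the cytotoxicity series

The source may hold more compounds than are shown below. What is called first, only, known or untested is meant among the compounds shown, and "the series" means these compounds.

Compound 1 `COc1c(F)c(N)c2c(=O)cc(-c3ccc(N)c(F)c3)oc2c1F` is the reference point. In a functional assay on HeLa cells (Homo sapiens) for cytotoxicity, read by neutral red uptake, with a stated time of 3 days (on this read-out higher numbers stand for weaker inhibition and lower numbers for stronger inhibition), compound 1 gives 34000 nM, the highest of the three numbers in hand. Compound 3 `Nc1ccc(-c2cc(=O)c3c(N)c(F)c(N)c(F)c3o2)cc1F` gives 19000 nM in this assay and is the nearest of the two others, a 1.8-fold lower number from compound 1 to compound 3 (0.25 log units; within the scatter). Compound 2 `[N-]=[N+]=Nc1c(F)c(N)c2c(=O)cc(-c3ccc(N)c(F)c3)oc2c1F` gives 1200 nM and is the furthest, a 28-fold lower number from compound 1 to compound 2 (1.45 log units; beyond the scatter). Between the two substituted analogues the gap is a 16-fold higher number from compound 2 to compound 3 (1.20 log units; beyond the scatter).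

Compound 4 `CCC(=O)OCc1c(F)c(N)c2c(=O)cc(-c3ccc(N)c(F)c3)oc2c1F` is not yet measured. It differs from compound 1 in one place: (propanoyloxy)methyl in place of methoxy on an aromatic carbon. The two measured steps that replace the same methoxy on the core bear on this change. The amino replacement, a 1.8-fold lower number from compound 1 to compound 3 (0.25 log units; within the scatter), stayed within the scatter, while the azido replacement, a 28-fold lower number from compound 1 to compound 2 (1.45 log units; beyond the scatter), was large. Among the compounds with values here, neither group resembles the (propanoyloxy)methyl that enters here, so there is no direct precedent for the ester, and the single large step rests on azido alone. The step is therefore expected to be modest, a 1.2-fold lower number from compound 1 to compound 4 (0.08 log units; within the scatter), with a wide margin of uncertainty. Compound 4 is estimated at 28000 nM in this assay, with an expected range from 7000 nM to 100000 nM.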

Compound 4, half-maximal inhibitory concentration: 69000 nM
Estimate against measurement, compound 4: 2.5-fold (0.39 log units) below, within the range that was stated.
By their numbers in this assay, from the lowest: compound 2; then compounds 3 and 1 (each within the scatter of the next); then compound 4.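

In this assay the place held by methoxy in compound 1 now shows a step toward a higher number beyond the scatter (a 2.0-fold higher number from compound 1 to compound 4 (0.31 log units; beyond the scatter)), whereas the amino replacement stayed within the scatter and the azido replacement gave a large step toward a lower number. The ester-bearing group also stands apart from both earlier replacements (a 3.6-fold higher number from compound 3 to compound 4 (0.56 log units; beyond the scatter); a 58-fold higher number from compound 2 to compound 4 (1.76 log units; beyond the scatter)), so compound 4 has the highest number of the four, with steps to all the others beyond the scatter, and this one place now spans a wider range of values on the shared core. No supporting measurement bears on why the number moves with this change.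

The compounds shown leave open whether the higher number follows the ester link or simply the longer chain, a question that hydroxymethyl, acetoxymethyl or a plain propoxymethyl ether at this place would address. They also leave open whether the large step toward a lower number is particular to azido or is shared by other small groups such as nitrile.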